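The source may report more compounds than this note shows. Statements on the series, on what has been measured and on what is new or still open speak of the compounds shown alone.

Compound 1 `CCCCCCCN1CCC(C(=O)Nc2cc(Cl)c(N)cc2OC)CC1` was examined in a functional assay on the whole organism for antagonist activity, with Mus musculus as the target; a lower number here means that less compound is needed, a higher number that more compound is needed for the effect. In this assay compound 1 gives > 10 mg/kg, and this is a limit of the assay, not a number. Two further compounds share the core of compound 1 and differ from it only in the group on a saturated chain carbon bound to an amine nitrogen in a ring. Compound 2 `COc1cc(N)c(Cl)cc1NC(=O)C1CCN(CC2CCCCCC2)CC1` gives > 10 mg/kg in this assay, again a limit. Compound 3 `COc1cc(N)c(Cl)cc1NC(=O)C1CCN(Cc2cccc(C#N)c2)CC1` gives > 4 mg/kg in this assay, also a limit. Compound 1 therefore stands at the limit of > 10 mg/kg in this assay, at which 2 of the 3 values shown sit. Compound 3 sits at the limit of > 4 mg/kg in this assay, at which 1 of the 3 values shown sits. The changes among these three are a step that the two limits leave unreadable from compound 1 to compound 2, a step that the two limits leave unreadable from compound 1 to compound 3 and a step that the two limits leave unreadable from compound 2 to compound 3; none of them has a readable size, so nothing measured yet shows how the group at this position moves the dose.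

Compound 4 `CCC(CC)CN1CCC(C(=O)Nc2cc(Cl)c(N)cc2OC)CC1` has not been measured. It differs from compound 1 in one place: pentan-3-yl in place of hexyl on a saturated chain carbon bound to an amine nitrogen in a ring. Since every step at this position is unreadable, no direction beyond the scatter can be expected in this assay, and another limit is the most likely outcome. The estimate for compound 4 in this assay is 15 mg/kg, with a range from 4 mg/kg to 50 mg/kg. The expected step is a step that the limit leaves unreadable from compound 1 to compound 4.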

Compound 4, dose for half-maximal effect: > 10 mg/kg
Compound 4: a limit, no number; the forecaster's own chance of this, stated with the estimate: 70%; the middle value lies beyond the limit too.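

In this assay compound 4 gives > 10 mg/kg, which is a limit and not a number, so its steps to compound 1, compound 2 and compound 3 cannot be read. The result adds one more value at the same limit: the limit of > 10 mg/kg in this assay, at which 3 of the 4 values shown sit. The compounds shown leave open whether, and how far, the group at this position moves the dose.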